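From methoxycarbonyl to pyrazin-2-yl: a half-life at the limit

The compounds below may be only part of what the source reports. "The series", "measured", "known", "first", "only" and "open" are said of these compounds alone.

Measured half-lives so far:
- compound 1 `C[C@H](O)[C@@H](CCc1ccc(C(F)(F)F)cc1)n1cnc2c(N)ncnc21` gives > 0.5 h
- compound 2 `C[C@H](O)[C@@H](CCC1CCCCC1)n1cnc2c(N)ncnc21` gives > 0.5 h
- compound 3 `COC(=O)c1cccc(CC[C@H]([C@H](C)O)n2cnc3c(N)ncnc32)c1` gives > 0.5 h

These half-lives come from an ADME assay on microsomes from liver (Mus musculus) for metabolic stability, read by LC-MS, using NADPH, with stated times of 5 min and 30 min, at 37 degrees C; a lower number here means that the compound disappears faster, a higher number that the compound lasts longer. In this assay, compound 3 stands at > 0.5 h, which is a limit and not a number. Compound 1 and compound 2 also stand at a limit, so the whole picture so far is the limit of > 0.5 h in this assay, at which 3 of the 3 values shown sit. Within the data shown here, no two of the measured compounds differ in one place only, so no measured step shows what a single change does here.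

Compound 4 `C[C@H](O)[C@@H](CCc1cccc(-c2cnccn2)c1)n1cnc2c(N)ncnc21` has not yet been measured. It differs from compound 3 in one group: pyrazin-2-yl in place of methoxycarbonyl on an aromatic carbon. In words, pyrazin-2-yl takes the place of methoxycarbonyl on an aromatic carbon of a six-membered aromatic ring of carbon only, meta to a large group.

With compound 3 at the limit of > 0.5 h, no step beyond the usual scatter is expected in this assay, in either direction. The expected step that the limit leaves unreadable from compound 3 to compound 4 is only an estimate. For compound 4, the estimated half-life is 0.7 h, with an expected range from 0.35 h to 1.4 h.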

Compound 4, half-life: > 0.5 h
Compound 4: only a limit was reported; the forecaster's own chance of this, stated with the estimate: 70%; the middle value lies beyond the limit too.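

Compound 3 and compound 4 both stand at a limit in this assay, so no step can be read for the exchange of methoxycarbonyl for pyrazin-2-yl: the limit of > 0.5 h in this assay, at which 4 of the 4 values shown sit. From the compounds shown here alone, how long any of these four compounds actually lasts, and whether either group gives the longer half-life, stays open.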